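The compounds below may be only part of what the source reports. "The series", "measured", "known", "first", "only" and "open" are said of these compounds alone.

Three compounds have been measured in a functional assay on U-937 cells (Homo sapiens) for cytotoxicity, read by MTT assay, with a stated time of 72 h; a higher number here means a weaker inhibitor, a lower number a stronger inhibitor:
compound 1 `Cc1c(C)c2c(c(C)c1O)CCC(C)(C(=O)NC1CC(C)(C)N([O])C(C)(C)C1)O2` gives 161000 nM;
compound 2 `Cc1c(C)c2c(c(C)c1OC(=O)CCC(=O)O)CCC(C)(C(=O)NC1CC(C)(C)N([O])C(C)(C)C1)O2` gives 123000 nM;
compound 3 `Cc1c(C)c2c(c(C)c1OC(=O)CCC(=O)O)CCC(C)(C(=O)NCC1CC(C)(C)N([O])C1(C)C)O2` gives 24000 nM.

Compound 2 stands second highest of these three numbers. Its nearest number belongs to compound 1 and its furthest to compound 3; the two steps are a 1.3-fold lower number from compound 1 to compound 2 (0.12 log units; within the scatter) and a 5.1-fold lower number from compound 2 to compound 3 (0.71 log units; beyond the scatter).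

Compound 4 `Cc1c(C)c2c(c(C)c1OC(=O)CCC(=O)NC1CC(C)(C)N([O])C(C)(C)C1)CCC(C)(C(=O)NC1CC(C)(C)N([O])C(C)(C)C1)O2` is not yet measured. It differs from compound 2 in one place: a group of 12 heavy atoms (9 carbon, 2 nitrogen, 1 oxygen; one six-membered non-aromatic ring with 1 hetero atom) in place of one oxygen atom, on a carbonyl carbon.

Neither measured step touches this place. The step from compound 1 to compound 2 altered the oxygen on the aromatic ring and stayed within the scatter. The step from compound 2 to compound 3 exchanged the ring on the amide-type nitrogen and was modest. Nothing shown bears directly on a change at the carbonyl carbon of the (2-carboxyethyl)carbonyl group, so compound 4 is expected to sit near compound 2, with no step beyond the scatter expected: a 1.2-fold lower number from compound 2 to compound 4 (0.09 log units; within the scatter). Compound 4 is estimated at 100000 nM, within 35000 nM to 300000 nM.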

Compound 4, half-maximal inhibitory concentration: 72000 nM
Beside the measured number, compound 4's estimate is 1.4-fold (0.14 log units) above it; low and high end bracket the measured number.
By their numbers in this assay, from the lowest: compound 3; then compounds 4, 2 and 1 (each within the scatter of the next, the first and the last beyond it).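

Among the compounds shown here, the earlier compounds left the carbonyl carbon of the side chain untouched, and this result is the first reading there. In this assay, putting the group of 12 heavy atoms, with its six-membered non-aromatic ring, in place of the hydroxy on this carbonyl carbon gives a 1.7-fold lower number from compound 2 to compound 4 (0.23 log units; within the scatter). So even an exchange this large, which removes the free carboxylic acid of compound 2, leaves the number within the scatter, and the hydroxy is not needed to keep the reading at this level. No measured evidence accounts for this reading.

From the compounds shown here alone, whether a methyl ester or a simple methylamine amide on this carbonyl carbon would read the same stays open. So does the effect of a longer chain in place of the saturated chain carbons leading to it.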